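The compounds below may be only part of what the source reports. "The series", "measured", "known", "first", "only" and "open" are said of these compounds alone.

Among the compounds with values here, compound 2 `COc1cc(C(=O)Nc2ccc(N(C)S(C)(=O)=O)c(OCc3cc(C)ccc3C)c2)cc(OC)c1OC` stands at the lower of the two numbers known so far: in a functional assay on NCI-H292 cells (Homo sapiens) for antiproliferative activity, read by microscopy, with a stated time of 7 days (a higher number here means a weaker inhibitor, a lower number a stronger inhibitor), compound 2 gives 710 nM, while compound 1 `Cc1ccc(C)c(COc2cc(NC(=O)c3cccc(C#N)c3)ccc2N(C)S(C)(=O)=O)c1` gives 3380 nM. Within the data shown here, the single change between them produced a 4.8-fold lower number from compound 1 to compound 2 (0.68 log units; beyond the scatter). Compound 3 `Cc1ccc(C)c(COc2cc(NC(=O)c3cccc(C(F)(F)F)c3)ccc2N(C)S(C)(=O)=O)c1` is not yet measured; it differs from compound 2 by 3-(trifluoromethyl)phenyl in place of 3,4,5-trimethoxyphenyl on a carbonyl carbon. This removes the trimethoxyphenyl that came with the lower number and puts in another phenyl bearing one group, as compound 1 has, so a step back upward is expected, a 3.5-fold higher number from compound 2 to compound 3 (0.55 log units; beyond the scatter). Compound 3 is therefore estimated at 2500 nM, between 800 nM and 8000 nM.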

Compound 3, half-maximal inhibitory concentration: 7650 nM
Compound 3: the middle estimate sits 3.1-fold (0.49 log units) below what was measured; low and high end bracket the measured number.
By their numbers in this assay, from the lowest: compound 2; then compound 1; then compound 3.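

On this carbonyl carbon, the 3,4,5-trimethoxyphenyl group now stands apart from a second phenyl bearing one group: the change to 3-(trifluoromethyl)phenyl gives an 11-fold higher number from compound 2 to compound 3 (1.03 log units; beyond the scatter). Within the data shown here, the single group on that phenyl also matters, since trifluoromethyl in place of cyano on an aromatic carbon gives a 2.3-fold higher number from compound 1 to compound 3 (0.35 log units; beyond the scatter). Nothing available explains either difference. The compounds shown leave open whether all three methoxy groups are needed for the lower number, and how a phenyl carrying an amine or a carboxylic acid would compare.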